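Dichloropurine series: cytotoxicity in MDA-MB-231 cells

A few compounds are considered here, and "the series" means these few. Any claim that something is new, unique, unknown or untested is made for them only; others in the source may bear on it.

Measured compounds:
compound 1 `ClCc1ccccc1Cn1cnc2c(Cl)nc(Cl)nc21`, 1380 nM
compound 2 `ClCc1ccccc1Cn1cnc2c(Cl)ncnc21`, 7410 nM
compound 3 `ClCc1cccc(Cn2cnc3c(Cl)ncnc32)c1`, 4070 nM

In a functional assay on MDA-MB-231 cells (Homo sapiens) for cytotoxicity, read by sulforhodamine B assay, with a stated time of 48 h (on this read-out higher numbers stand for weaker inhibition of growth and lower numbers for stronger inhibition of growth), compound 1 gives 1380 nM, compound 2 gives 7410 nM and compound 3 gives 4070 nM. The step from compound 2 to compound 1 is chloro in place of hydrogen on an aromatic carbon, and it gave a 5.4-fold lower number from compound 2 to compound 1 (0.73 log units; beyond the scatter). The difference between the cores of compound 2 and compound 3 is not broken down here; their two values lie within the scatter of each other.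

Compound 4 `ClCc1cccc(Cn2cnc3c(Cl)nc(Cl)nc32)c1` has not yet been measured in this assay. It differs from compound 3 by chloro in place of hydrogen on an aromatic carbon, the same change seen from compound 2 to compound 1. This change is expected to give a step of about a 5.1-fold lower number from compound 3 to compound 4 (0.71 log units; beyond the scatter) from compound 3 to compound 4, resting on a 5.4-fold lower number from compound 2 to compound 1 (0.73 log units; beyond the scatter). On that basis compound 4 is estimated at 800 nM, with a range from 350 nM to 1800 nM.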

Compound 4, concentration for total growth inhibition: 3710 nM
Beside the measured number, compound 4's estimate is 4.6-fold (0.67 log units) below it; measured number above the stated range.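

In this assay, chloro in place of hydrogen on an aromatic carbon gave a 1.1-fold lower number from compound 3 to compound 4 (0.04 log units; within the scatter). The step therefore does not carry over at the same size between these two cores: the same change on two cores in this assay, a 5.4-fold lower number (0.73 log units; beyond the scatter) from compound 2 to compound 1 and a 1.1-fold lower number (0.04 log units; within the scatter) from compound 3 to compound 4, 4.9-fold (0.69 log units) apart, beyond the scatter of two such steps

These two pairs show only that the size of this step differs with the core; they do not show what in the cores sets the two steps apart, and they give no rule for a further core. The compounds shown leave open how an amine or a methoxy group on that same carbon, between two ring nitrogen atoms, would read in this assay. Going by these compounds, whether either group would separate the two cores as chloro does also remains open.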